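Acetyl on the Ring Nitrogen: Tolerance in MT4 Cells

The source may report more compounds than this note shows. Statements on the series, on what has been measured and on what is new or still open speak of the compounds shown alone.

Compound 1 `O=c1[nH]c2ccc(Cl)cc2n1Cc1c(F)cccc1F` — > 424000 nM
Compound 2 `CC(=O)n1c(=O)n(Cc2c(F)cccc2F)c2cc(Cl)ccc21` — > 5950 nM
Compound 3 `O=c1[nH]c2ccc(Cl)cc2n1Cc1cc(F)cc(F)c1` — > 424000 nM

In an ADME assay on MT4 cells (Homo sapiens) for cytotoxicity (a higher number here means that more compound is tolerated, a lower number that less compound is tolerated), compound 1 gives > 424000 nM, which is a limit of the assay rather than a number. Compound 3 likewise returns only a limit, > 424000 nM. Compound 2 gives > 5950 nM, again a limit. The change from compound 1 to compound 2 is acetyl in place of hydrogen on an aromatic nitrogen; the step that the two limits leave unreadable from compound 1 to compound 2 cannot be read, since the limit of > 424000 nM in this assay, at which 2 of the 3 values shown sit, and the limit of > 5950 nM in this assay, at which 1 of the 3 values shown sits, both cap what is seen. Compound 1 and compound 3 hold the same atoms joined differently; the difference between the two cores is not broken down here. Compound 4 `CC(=O)n1c(=O)n(Cc2cc(F)cc(F)c2)c2cc(Cl)ccc21` carries the same change on compound 3, (acetyl in place of hydrogen on an aromatic nitrogen). Among the measured compounds shown here, because a step that the two limits leave unreadable from compound 1 to compound 2 is the only measured step for this change and its size is not readable, compound 4 is expected to be tolerated similarly, an expected step of an at least 7.0-fold lower number from compound 3 to compound 4 (0.84 log units; beyond the scatter). The estimate for compound 4 is 60000 nM, between 6000 nM and 424000 nM.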

Compound 4, half-maximal cytotoxic concentration: 40400 nM
Estimate against measurement, compound 4: 1.5-fold (0.17 log units) above; the measured number falls inside the stated range.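

In this assay, acetyl in place of hydrogen on an aromatic nitrogen gives an at least 10-fold lower number from compound 3 to compound 4 (1.02 log units; beyond the scatter), so on the core of compound 3 the change clearly lowers the number. Among the compounds shown here, the same change on the core of compound 1 cannot be read, so the series holds only one readable step and does not show that its size carries from one core to the other. The full size of the readable step also stays unknown, since compound 3 returns only a limit: the limit of > 424000 nM in this assay, at which 2 of the 4 values shown sit.

The compounds shown leave open whether a group other than acetyl on that aromatic nitrogen, such as methyl, a longer chain or a carboxylic acid, would give a similar step in this assay. They also leave open whether the step would hold on a core without the chlorine.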